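Methylphenyl Replacing Chlorophenyl: Expected Cytotoxicity of Compound 3

The source may hold more compounds than are shown below. What is called first, only, known or untested is meant among the compounds shown, and "the series" means these compounds.

Compound 2 `N#Cc1c(-c2cccc(Cl)c2)c(C#N)c(=O)n(/N=C/c2cn(-c3ccccc3)nc2-c2ccccc2)c1N` was tested in an ADME assay on HeLa cells (Homo sapiens) for cytotoxicity, read by MTT assay; a higher number here means a weaker inhibitor, a lower number a stronger inhibitor. In this assay compound 2 reaches only a limit, > 200 ug/mL, not a number. Its relative compound 1 `N#Cc1c(-c2ccccc2O)c(C#N)c(=O)n(/N=C/c2cn(-c3ccccc3)nc2-c2ccccc2)c1N` likewise gives only a limit in this assay, > 200 ug/mL. The step that the two limits leave unreadable from compound 1 to compound 2 therefore cannot be read. Compound 3 `Cc1ccc(-c2c(C#N)c(N)n(/N=C/c3cn(-c4ccccc4)nc3-c3ccccc3)c(=O)c2C#N)cc1` differs from compound 2 by 4-methylphenyl in place of 3-chlorophenyl on an aromatic carbon. Among the measured compounds shown here, no measured step tells the direction of this change. Since compound 1 and compound 2 both sit at the limit of > 200 ug/mL in this assay, at which 2 of the 2 values shown sit, compound 3 is expected to stay there too, an expected step that the limit leaves unreadable from compound 2 to compound 3. The estimate for compound 3 is 250 ug/mL, between 120 ug/mL and 600 ug/mL.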

Compound 3, half-maximal inhibitory concentration: > 200 ug/mL
Compound 3 was reported as a limit (the forecaster's own chance of this, stated with the estimate: 80%); the middle value is on the limit's open side.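

No step among compound 1, compound 2 and compound 3 can be read, because all three reach only a limit: the limit of > 200 ug/mL in this assay, at which 3 of the 3 values shown sit.

From the compounds shown here alone, whether any group on this aromatic carbon would give a readable number in this assay remains open.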